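The compounds below may be only part of what the source reports. "The series", "measured", "known", "first", "only" and "open" are said of these compounds alone.

Measured compounds in a functional assay on A549 cells (Homo sapiens) for antiproliferative activity, read by MTT assay, with a stated time of 72 h; on this read-out lower numbers stand for stronger inhibition and higher numbers for weaker inhibition:
Compound 1 `C#Cc1cccc(Nc2ncnc3cc(OC)c(OCCCCC(=O)Nc4ccc(S(N)(=O)=O)cc4)cc23)c1` gives 7720 nM.
Compound 2 `COc1cc2ncnc(Nc3ccc(F)cc3)c2cc1OCCCCC(=O)Nc1ccc(S(N)(=O)=O)cc1` reaches only the assay limit, > 40000 nM.
Compound 3 `COc1ccc(Nc2ncnc3cc(OC)c(OCCCCC(=O)Nc4ccc(S(N)(=O)=O)cc4)cc23)cc1` likewise reaches only the assay limit, > 40000 nM.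

Compound 2 thus stands at the top of the shown values, with no number of its own; compound 3 sits at the same limit (the limit of > 40000 nM in this assay, at which 2 of the 3 values shown sit), and only compound 1 yields a readable value. Both changes of the aryl group on the amine nitrogen away from compound 1, an at least 5.1-fold higher number from compound 1 to compound 2 (0.71 log units; beyond the scatter) and an at least 5.1-fold higher number from compound 1 to compound 3 (0.71 log units; beyond the scatter), run in the same direction. The step between the two limit compounds, a step that the two limits leave unreadable from compound 2 to compound 3, cannot be read.

Compound 4 `COc1cc2ncnc(Nc3ccc(C)cc3)c2cc1OCCCCC(=O)Nc1ccc(S(N)(=O)=O)cc1` differs from compound 2 by methyl in place of fluoro on an aromatic carbon. The closest comparison is the methoxy-for-fluoro exchange at the same place, which gives no size. Nothing shown suggests the methyl group would recover the potency lost on leaving 3-ethynylphenyl, so compound 4 is expected to remain near the limit, and the expected step is a number no higher from compound 2 to compound 4 (the limit leaves the size open). The estimate for compound 4 is 40000 nM, in the range 15000 nM to 90000 nM.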

Compound 4, half-maximal inhibitory concentration: > 40000 nM
Compound 4 ended at the assay's limit; the forecaster's own chance of this, stated with the estimate: 65%; the middle value sits exactly at the limit.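

Methyl is a third group, after fluoro and methoxy, whose exchange for 3-ethynylphenyl on the amine nitrogen moves the number the same way in this assay: an at least 5.1-fold higher number from compound 1 to compound 4 (0.71 log units; beyond the scatter). The steps among compound 2, compound 3 and compound 4 cannot be read, so fluoro, methoxy and methyl cannot be ranked against one another at this place. Among the shown compounds, only compound 1 gives a readable value, and the limit now holds most of the set: the limit of > 40000 nM in this assay, at which 3 of the 4 values shown sit.

Open is whether the ethynyl group itself or its place on the ring separates compound 1 from the others, as each change shown alters both. A nitrile or an amine on this aromatic carbon, or a longer chain on the ether oxygen, could show whether a compound without 3-ethynylphenyl can give a readable value.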